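The source may hold more compounds than are shown below. What is called first, only, known or untested is meant among the compounds shown, and "the series" means these compounds.

Measured so far in a functional assay on MCF7 cells (Homo sapiens) for cytotoxicity, read by MTT assay, with a stated time of 72 h; on this read-out higher numbers stand for weaker inhibition and lower numbers for stronger inhibition:
- compound 1 `COc1ccc(/C=C2\CCC/C(=C\c3cccc(OC)c3OC)C2=O)cc1`: 18600 nM
- compound 2 `COc1ccc(/C=C2\CCC/C(=C\c3cccc(OC)c3OC)C2=O)c(OC)c1`: > 20000 nM, a limit of the assay and not an exact number
- compound 3 `COc1ccc(/C=C2\CCC/C(=C\c3cccc(OC)c3OC)C2=O)cc1OC`: 6500 nM

Of the two exact numbers, compound 1 has the higher, 18600 nM. The other exact number is lower, as the step of a 2.9-fold lower number from compound 1 to compound 3 (0.46 log units; beyond the scatter) shows.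

Compound 4 `COc1cccc(/C=C2\CCC/C(=C\c3ccc(O)c(Cl)c3)C2=O)c1OC` has 3-chloro-4-hydroxyphenyl in place of 4-methoxyphenyl on a double-bonded chain carbon bound to a double-bonded ring carbon.

Two measured steps change that same 4-methoxyphenyl group, each putting methoxy in place of hydrogen on an aromatic carbon. The step of an at least 1.0-fold higher number from compound 1 to compound 2 (0.03 log units; that floor lies within the scatter) does not go beyond the scatter, whereas the step of a 2.9-fold lower number from compound 1 to compound 3 (0.46 log units; beyond the scatter) is modest but real. Neither step introduces chlorine or a hydroxy group, so both are only a loose guide. Compound 3 points to a lower number, and compound 2 does not follow it. A modest drop is therefore expected in this assay, with considerable uncertainty. The expected change is a 2.7-fold lower number from compound 1 to compound 4 (0.42 log units; beyond the scatter).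

For compound 4, the estimate is 7000 nM, with an expected range from 2000 nM to 19000 nM.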

Compound 4, half-maximal inhibitory concentration: 16400 nM
The estimate for compound 4 lay 2.3-fold (0.37 log units) below the measured number; measured number inside the range.
By their numbers in this assay, from the lowest: compound 3; then compounds 4 and 1 (each within the scatter of the next). At a limit, above all of these: compound 2.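

In this assay, replacing the whole 4-methoxyphenyl group with 3-chloro-4-hydroxyphenyl on a double-bonded chain carbon bound to a double-bonded ring carbon leaves the number within the scatter (a 1.1-fold lower number from compound 1 to compound 4 (0.05 log units; within the scatter)). Within the data shown here, the earlier steps at this group only added a methoxy, so this is the first sign that the position accepts a group carrying chlorine and a hydrogen-bond donor with no change beyond the scatter. It also shows that the lower number of compound 3 (a 2.9-fold lower number from compound 1 to compound 3 (0.46 log units; beyond the scatter)) is not shared by every compound with a changed ring at this place.

From the compounds shown here alone, what 3-chlorophenyl alone, 4-hydroxyphenyl alone, or a phenyl ring bearing an amine or a carboxylic acid would give here remains open. Nothing shown gives a measured reason for these numbers.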